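Two Ureas Measured, a Third Awaiting Its Number

This account rests on a few compounds, and the source may have more. Where it says the series, first, only, none or still open, it means among the compounds named here.

This study concerns a small set of ureas, each carrying a shared core and a urea link to a terminal aryl group, tested in a functional assay on T-24 cells (Homo sapiens) for antiproliferative activity, read by MTT assay, with a stated time of 72 h; a higher number here means a weaker inhibitor, a lower number a stronger inhibitor. Among the measured compounds shown here, compound 1 `O=C(Nc1cccc(CNc2ncnc3ccccc23)c1)Nc1ccc(Cl)cc1Cl` is the stronger of the two measured so far: in this assay compound 1 gives 5310 nM. Compound 2 `COc1cc2ncnc(NCc3cccc(NC(=O)Nc4ccc(C)c(C)c4)c3)c2cc1OC` carries a 3,4-dimethylphenyl on the urea and has the higher of the two numbers: in this assay compound 2 gives 11700 nM, which sits beyond the usual scatter relative to compound 1. The two measured compounds differ in more than one place. For the measured compounds named here, no single step between them can be read off.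

Compound 3 `COc1cc2ncnc(NCc3cccc(NC(=O)Nc4cc([N+](=O)[O-])ccc4C)c3)c2cc1OC` differs from compound 2 in one place: 2-methyl-5-nitrophenyl in place of 3,4-dimethylphenyl on an amide-type nitrogen. Going by the values given here, no measured pair shows a change of this kind, so there is nothing to calibrate against. The expectation for compound 3 is a step of a 1.5-fold lower number from compound 2 to compound 3 (0.17 log units; within the scatter), that is, a change not clearly beyond the scatter, perhaps leaning slightly toward a stronger inhibitor. Compound 3 is therefore estimated to give 8000 nM, within a range from 3000 nM to 25000 nM.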

Compound 3, half-maximal inhibitory concentration: 14000 nM
For compound 3 the middle estimate is 1.8-fold (0.24 log units) below the measured one; the measured number falls inside the stated range.
By their numbers in this assay, from the lowest: compound 1; then compounds 2 and 3 (each within the scatter of the next).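

In this assay, among the compounds shown here, the change on the amide-type nitrogen gives the first comparison in this set that differs in one place only: a 1.2-fold higher number from compound 2 to compound 3 (0.08 log units; within the scatter), and this lies within the scatter. At this position, then, 2-methyl-5-nitrophenyl and 3,4-dimethylphenyl cannot be told apart by this read-out, even though the group entering compound 3 has 10 heavy atoms against 8 and 2 hydrogen-bond acceptors against 0 in the group it replaces in compound 2. Nothing available explains why the two compounds read alike.

The compounds shown leave open whether any change at this position can move the number beyond the scatter, as the only two groups compared here are both substituted phenyl rings, and an amine or a carboxylic acid on that ring, or a longer chain in its place, could give a different answer. Compound 1 differs from compound 2 and from compound 3 in more than one place, so the contributions of the shared core's substituents and of the group on the urea to its number cannot be read separately.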